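The source may hold more compounds than are shown below. What is called first, only, known or untested is meant among the compounds shown, and "the series" means these compounds.

The measured compounds:
compound 1 `COc1ccccc1-n1nc(C2CC(C)(C)OC(C)(C)C2)cc1-c1ccc(C#N)cc1`, in an assay on HEK293 cells for inhibition of Voltage-dependent N-type calcium channel subunit alpha-1B (Homo sapiens), read by patch clamp, using a membrane potential dye (a lower number here means a stronger inhibitor, a higher number a weaker inhibitor), compound 1 gives 85 nM.
compound 2 `COc1ccccc1-n1nc(C2CCOC(C)(C)C2)cc1-c1ccc(Cl)cc1`, compound 2 gives 55 nM.
compound 3 `COc1ccccc1-n1nc(C2C[C@H](C)O[C@@H](C)C2)cc1-c1ccc(Cl)cc1`, compound 3 gives 61000 nM.

Among these three numbers compound 1 stands second highest. Its nearest neighbour is compound 2, whose number is lower by an amount within the scatter; compound 3 is far away, with a number well beyond the scatter higher than that of compound 1. Among the measured compounds shown here, the only single-point step among the measured compounds is a 1100-fold higher number from compound 2 to compound 3 (3.04 log units; beyond the scatter), which concerns the oxane ring and not the aromatic group attached to the core.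

Compound 4 `COc1ccccc1-n1nc(C2CC(C)(C)OC(C)(C)C2)cc1-c1csc(Cl)c1` differs from compound 1 in one place: 5-chlorothiophen-3-yl in place of 4-cyanophenyl on an aromatic carbon. For the measured compounds named here, no measured step touches this position. Compounds 1 and 2 differ in two places, one of them the group on the same aromatic carbon, and their numbers lie within the scatter of each other, which offers a weak hint that this position tolerates exchange. That hint is indirect. The step is expected to be small, and no direction beyond the scatter is predicted; the expected step is a 1.4-fold higher number from compound 1 to compound 4 (0.15 log units; within the scatter). Compound 4 is therefore estimated at 120 nM, within a range from 30 nM to 500 nM.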

Compound 4, half-maximal inhibitory concentration: 28 nM
Beside the measured number, compound 4's estimate is 4.3-fold (0.63 log units) above it, outside the stated range (below it).
By their numbers in this assay, from the lowest: compounds 4, 2 and 1 (each within the scatter of the next, the first and the last beyond it); then compound 3.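

In this assay, the exchange of 4-cyanophenyl for 5-chlorothiophen-3-yl gives a 3.0-fold lower number from compound 1 to compound 4 (0.48 log units; beyond the scatter) on the otherwise unchanged structure of compound 1. Among the compounds shown here, this is the first direct reading at this aromatic carbon, where the earlier compounds offered only a pair that differed in two places, and it shows that the position responds to the group it carries by a modest step beyond the scatter. A six-membered aromatic ring of carbon only can thus give way to a five-membered aromatic ring with 1 hetero atom with no loss of inhibition, although no measurement shown here accounts for the change.

For the compounds shown here, the single pair cannot separate the exchange of ring from the exchange of nitrile for chlorine, so a plain thiophen-3-yl group or a 4-chlorophenyl group on the core of compound 1 remains an open case. As far as these compounds go, it also remains open whether the position would accept a group carrying an amine or a carboxylic acid, and whether 5-chlorothiophen-3-yl would have a similar effect alongside 2,2-dimethyloxan-4-yl.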